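The compounds below may be only part of what the source reports. "The series", "measured", "known", "first", "only" and "open" are said of these compounds alone.

Of the compounds shown here, three built on a shared core have been measured in a functional assay on Molt4/C8 cells (Homo sapiens) for cytotoxicity; a lower number here means a stronger inhibitor, a higher number a weaker inhibitor. Compound 1 `Cc1cccc(C)c1NC(=O)/C=C/C(=O)N1C/C(=C\c2ccccc2)C(=O)/C(=C/c2ccccc2)C1` gives 6600 nM, compound 2 `Cc1cccc(C)c1NC(=O)/C=C/C(=O)N1C/C(=C\c2ccc([N+](=O)[O-])cc2)C(=O)/C(=C/c2ccc([N+](=O)[O-])cc2)C1` gives 210 nM, and compound 3 `O=C(/C=C/C(=O)N1C/C(=C\c2ccccc2)C(=O)/C(=C/c2ccccc2)C1)Nc1ccccc1` gives 520 nM. Compound 2 has the lowest number of the three, and its gaps to compound 3 and to compound 1 both lie beyond the scatter. How the core of compound 2 differs from the core of compound 1 is not broken down here. Compound 3 differs from compound 1 in one place only (phenyl in place of 2,6-dimethylphenyl on an amide-type nitrogen), and that step gave a 13-fold lower number from compound 1 to compound 3 (1.10 log units; beyond the scatter). Compound 4 `O=C(/C=C/C(=O)N1C/C(=C\c2ccc([N+](=O)[O-])cc2)C(=O)/C(=C/c2ccc([N+](=O)[O-])cc2)C1)Nc1ccccc1` has not yet been measured; it carries the same change, at the same place, on the core of compound 2 (phenyl in place of 2,6-dimethylphenyl on an amide-type nitrogen). Going by the values given here, because of the large step of a 13-fold lower number from compound 1 to compound 3 (1.10 log units; beyond the scatter), a step in the same direction is expected here as well, though with only one earlier example to rest on it may well come out somewhat smaller. The expected step is a 5.3-fold lower number from compound 2 to compound 4 (0.72 log units; beyond the scatter). Compound 4 is therefore estimated at 40 nM, with a likely range from 10 nM to 150 nM.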

Compound 4, half-maximal inhibitory concentration: 360 nM
The estimate for compound 4 lay 9.0-fold (0.95 log units) below the measured number, and the stated range ends below it.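

On the core of compound 2, phenyl in place of 2,6-dimethylphenyl on the amide-type nitrogen gave a 1.7-fold higher number from compound 2 to compound 4 (0.23 log units; within the scatter) in this assay, so no real change can be read from this step, whereas the same swap on the core of compound 1 had a large effect. The size of this change therefore did not carry over from one core to the other: the same change on two cores in this assay, a 13-fold lower number (1.10 log units; beyond the scatter) from compound 1 to compound 3 and a 1.7-fold higher number (0.23 log units; within the scatter) from compound 2 to compound 4, 22-fold (1.34 log units) apart, beyond the scatter of two such steps. Going by these compounds alone, this shows that the result on one core was a poor guide to the result on the other, but with only two pairs it does not show which part of the cores is responsible, nor how the change would behave on any further core.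

The compounds shown leave open whether a core with methoxy or chloro groups in place of the nitro groups would follow the large step or the small one. They also leave open how a benzyl or cyclohexyl group on the same amide-type nitrogen would compare with phenyl and 2,6-dimethylphenyl on each core.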